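A Diamine Tail in Place of a Hydroxyhexyl Ester

The source may hold more compounds than are shown below. What is called first, only, known or untested is meant among the compounds shown, and "the series" means these compounds.

Compound 1 `Cc1cn(C2CC(N=[N+]=[N-])C(COC(=O)OCCCC(=O)OC(C)(C)C)O2)c(=O)[nH]c1=O` — in a functional assay on MT4 cells (Homo sapiens) for cytotoxicity (on this read-out higher numbers stand for lower toxicity in this test and lower numbers for higher toxicity in this test), compound 1 gives > 50000 nM, which is a limit of the assay.
Compound 2 `Cc1cn(C2CC(N=[N+]=[N-])C(COC(=O)OCCCCCCO)O2)c(=O)[nH]c1=O` — in this assay compound 2 gives > 50000 nM, which is a limit of the assay.
Compound 3 `Cc1cn(C2CC(N=[N+]=[N-])C(COC(=O)CCCC(=O)O)O2)c(=O)[nH]c1=O` — in this assay compound 3 gives > 50000 nM, which is a limit of the assay.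

Compound 2 therefore stands only at a limit, with no number of its own, and the same holds for the two compounds around it, as all three sit at the limit of > 50000 nM in this assay, at which 3 of the 3 values shown sit. The step that the two limits leave unreadable from compound 1 to compound 2 and the step that the two limits leave unreadable from compound 2 to compound 3 are both unreadable for that reason, so neither gives a usable size in either direction.

Compound 4 `Cc1cn(C2CC(N=[N+]=[N-])C(COC(=O)NCCCN)O2)c(=O)[nH]c1=O` carries (3-aminopropyl)amino in place of (6-hydroxyhexyl)oxy on a carbonyl carbon. The two measured steps that bear on it cannot show whether a change on this carbonyl carbon moves the read-out at all. The account expects compound 4 to remain at the limit, with an expected step of a number no higher from compound 2 to compound 4 (the limit leaves the size open) that is not beyond the scatter. On that basis compound 4 is estimated at 50000 nM, within a range from 20000 nM to 150000 nM.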

Compound 4, half-maximal cytotoxic concentration: > 50000 nM
Compound 4 ended at the assay's limit; the forecaster's own chance of this, stated with the estimate: 85%; the middle value sits exactly at the limit.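

In this assay compound 4 gives > 50000 nM, which is a limit of the assay. Among these compounds, no step from compound 2 or compound 3 to compound 4 can therefore be read. The compounds shown leave open whether any change on this carbonyl carbon moves the read-out, because all of them stand at one value: the limit of > 50000 nM in this assay, at which 4 of the 4 values shown sit.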